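A few compounds are considered here, and "the series" means these few. Any claim that something is new, unique, unknown or untested is made for them only; others in the source may bear on it.

Compound 3 `CCOC(=O)c1cn(-c2ccc(F)cc2)nc1CC(C)C` stands at the edge of what a toxicity assay on HepG2 2.2.15 cells (Homo sapiens) for cytotoxicity, read by CCK-8 assay, with a stated time of 8 days (a lower number here means that less compound is tolerated, a higher number that more compound is tolerated), can report: in this assay compound 3 gives > 100000 nM, which is a limit of the assay and not a number. Compound 1 `CCOC(=O)c1cn(-c2nccs2)nc1CC(C)C` likewise gives > 100000 nM in this assay, a limit. Compound 2 `CCOC(=O)c1cn(-c2ccccc2F)nc1CC(C)C` gives > 100000 nM in this assay, again a limit. Because all three values sit at the limit of > 100000 nM in this assay, at which 3 of the 3 values shown sit, the steps a step that the two limits leave unreadable from compound 1 to compound 2, a step that the two limits leave unreadable from compound 1 to compound 3 and a step that the two limits leave unreadable from compound 2 to compound 3 have no readable size. Compound 4 `CCOC(=O)c1cn(-c2ccc(OC)cc2)nc1CC(C)C` differs from compound 3 by methoxy in place of fluoro on an aromatic carbon. Within the data shown here, no measured step carries a readable size onto this change. The expected step is a number no higher from compound 3 to compound 4 (the limit leaves the size open), none beyond the scatter. Compound 4 is therefore estimated at 100000 nM, between 50000 nM and 200000 nM, most likely again a limit.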

Compound 4, half-maximal cytotoxic concentration: 77100 nM
The estimate for compound 4 lay 1.3-fold (0.11 log units) above the measured number, and the stated range covers the measured number.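

Methoxy in place of fluoro on an aromatic carbon gives an at least 1.2-fold lower number from compound 3 to compound 4 (0.11 log units; that floor lies within the scatter), so this change at this place yields a readable number, though the floor of the step stays within the scatter. Compound 4 is the only compound shown with a number rather than a limit: the limit of > 100000 nM in this assay, at which 3 of the 4 values shown sit.

On these data alone, how large the step truly is stays open, since one of its two ends is only a limit. Also open, as far as these compounds go, is how an amine, a carboxylic acid or a longer alkoxy chain at this place would read in this assay.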